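The source may report more compounds than this note shows. Statements on the series, on what has been measured and on what is new or still open speak of the compounds shown alone.

Values in a physicochemical assay for lipophilicity, at pH 7.4 (a higher number here means a more lipophilic compound, a lower number a more polar compound), so far

compound 1 (`O=C(NC1CC1)C1CCN(c2cnccc2-c2ccccc2)CC1`) 2.5
compound 2 (`CNC(=O)C1CCN(c2cncnc2-c2ccccc2)CC1`) 1.4
compound 3 (`CN(C)C(=O)C1CCN(c2cnccc2-n2cccn2)CC1`) 1.1

Compound 3 (1.1) lies within the usual scatter of compound 2 (1.4), so these two cannot be told apart on this measurement. Compound 1 (2.5) stands clearly higher than compound 3, beyond the scatter.

The next compound to be measured is compound 4 (`Cc1ccn(-c2ccncc2N2CCC(C(=O)N(C)C)CC2)n1`). It differs from compound 3 by one small change (methyl in place of hydrogen on an aromatic carbon), methyl in place of hydrogen on an aromatic carbon, which turns 1H-pyrazol-1-yl into 3-methyl-1H-pyrazol-1-yl. Among the measured compounds shown here, no two measured compounds differ in only one place, so no measured step shows the size of this change, and the expectation rests on the structural change alone. A small rise in this assay is expected, an estimated a number 0.40 log units higher from compound 3 to compound 4 (beyond the scatter) and this may barely clear the scatter. The estimated value for compound 4 is 1.5 with an expected range from 1.1 to 1.9 as its ends.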

Compound 4, distribution coefficient: 1.5
The estimate for compound 4 equals the measured number at the digits printed, within the range that was stated.
By their numbers in this assay, from the lowest: compounds 3, 2 and 4 (each within the scatter of the next, the first and the last beyond it); then compound 1.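

Among the compounds shown here, compounds 3 and 4 form the first pair here that differs in only one place, so the size of a single change can now be read directly instead of being inferred from compounds that differ in several places. In this assay, replacing hydrogen with methyl on an aromatic carbon of the five-membered aromatic ring, which turns 1H-pyrazol-1-yl into 3-methyl-1H-pyrazol-1-yl, gives a number 0.40 log units higher from compound 3 to compound 4 (beyond the scatter) and so shows that this small change at this position can register beyond the scatter. No measurement shown explains the size of this step.

On these data alone, whether ethyl, a chlorine atom, an amine or a carboxylic acid at this position would move the number further, less or the other way remains open. One step also cannot show whether methyl would give a similar step on another aromatic carbon of this ring or on a different core.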